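Tetrazolyl to fluoropyridyl swap on the aryl end

The source may report more compounds than this note shows. Statements on the series, on what has been measured and on what is new or still open speak of the compounds shown alone.

Three measured compounds, all near one another. In a functional assay on HEK293 cells for agonist activity at Bombesin receptor subtype-3 (Mus musculus), read by luminescence and calcium flux, with a stated time of 10 min (a higher number here means that more compound is needed for the effect, a lower number that less compound is needed), compound 1 `c1ccc(-c2ccc(CCc3nc(CC4CCCC4)c[nH]3)cc2)nc1` gives 103 nM, compound 3 `O=C(O)c1cc(F)c(F)cc1-c1ccc(CCc2nc(CC3CCCCC3)c[nH]2)cc1` gives 96 nM, and compound 2 `CCC(C)(C)Cc1c[nH]c(CCc2ccc(-n3ncnn3)cc2)n1` gives 99 nM. Compound 2 stands second highest of the three, yet its gaps to compound 3 and to compound 1 both lie within the scatter, so no order among them can be read.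

Compound 4 `CCC(C)(C)Cc1c[nH]c(CCc2ccc(-c3ccc(F)cn3)cc2)n1` differs from compound 2 in one place: 5-fluoropyridin-2-yl in place of 2H-tetrazol-2-yl on an aromatic carbon. Among the measured compounds shown here, no measured pair shows this change, but compound 1 carries a pyridin-2-yl at the corresponding place and sits at 103 nM, close to compound 2. No step beyond the scatter is expected in either direction. Compound 4 is therefore estimated at 100 nM, in the range 40 nM to 250 nM, a step of a 1.0-fold higher number from compound 2 to compound 4 (0.00 log units; within the scatter) expected.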

Compound 4, half-maximal effective concentration: 105 nM
For compound 4 the middle estimate is 1.1-fold (0.02 log units) below the measured one; low and high end bracket the measured number.
By their numbers in this assay, from the lowest: compounds 3, 2, 1 and 4 (each within the scatter of the next).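

Among the compounds shown here, at this aromatic carbon, para to a large group, replacing 2H-tetrazol-2-yl with 5-fluoropyridin-2-yl gives in this assay a 1.1-fold higher number from compound 2 to compound 4 (0.03 log units; within the scatter) as the first direct reading of this change. With the rest of compound 2 held fixed, a five-membered aromatic ring with 4 hetero atoms and a six-membered aromatic ring with 1 hetero atom are not told apart at this place. No measurement offered here accounts for this result.
Still open, going by these compounds, is how a carboxylic acid or a primary amine on this aromatic carbon would read against the core of compound 2.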